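Benzyl in Place of Butoxy: What to Expect Next

This account rests on a few compounds, and the source may have more. Where it says the series, first, only, none or still open, it means among the compounds named here.

Compound 1, `COc1ccc(NC(=O)Nc2n[nH]c3ccccc23)cc1`: > 100000 nM
Compound 2, `CCCCOc1ccc(NC(=O)n2nc(N)c3ccccc32)cc1`: 14700 nM

Of the compounds shown here, two have so far been tested in a functional assay on UACC-62 cells (Homo sapiens) for inhibition, read by sulforhodamine B assay, with a stated time of 48 h; on this read-out lower numbers stand for stronger inhibition of growth and higher numbers for weaker inhibition of growth. For compound 1 the entry > 100000 nM is a limit of the assay and not a number. Compound 2 gives 14700 nM in this assay. Where compound 2 stands is simple to state: it holds the only number among the values shown, while the remaining entry is a limit, as recorded in the limit of > 100000 nM in this assay, at which 1 of the 2 values shown sits.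

Compound 3, `Nc1nn(C(=O)Nc2ccc(Cc3ccccc3)cc2)c2ccccc12`, is not yet measured. It differs from compound 2 in one place.

benzyl in place of butoxy on an aromatic carbon

Within the data shown here, no step between measured compounds is available to guide the size of this change, since the two measured compounds differ in more than one place and one of them gives only a limit. With one lipophilic group replaced by another of similar size, the expected step from compound 2 to compound 3 in this assay is a 1.2-fold lower number from compound 2 to compound 3 (0.09 log units; within the scatter), which is not expected to go beyond the usual scatter in either direction. Compound 3 is therefore estimated at 12000 nM, with a range from 3000 nM to 50000 nM.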

Compound 3, concentration for 50% growth inhibition: 353 nM
Beside the measured number, compound 3's estimate is 34-fold (1.53 log units) above it; the whole stated range lies above it.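

In this assay, benzyl in place of butoxy on an aromatic carbon, para to a large group, gives a 42-fold lower number from compound 2 to compound 3 (1.62 log units; beyond the scatter), so this position is clearly sensitive to which of these two groups it carries. Compound 1 could not show this: its entry of > 100000 nM is a limit of the assay and not a number, and it differs from compound 2 in more than one place, which leaves this step as the only one in the series that can be sized. Nothing among the data shown gives a measured property that bears on this step, so its cause remains unassigned.

The step swaps two things at once, since butoxy brings an oxygen and no ring while benzyl brings a ring and no oxygen, and the compounds shown cannot say which of these accounts for the change in the number. A phenoxy group, which keeps both the oxygen and a ring, or a pentyl chain, which has neither, would help to separate the two at this same place.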